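The compounds below may be only part of what the source reports. "The series", "measured", "known", "first", "only" and "open" are said of these compounds alone.

Measured compounds:
Compound 1 `COc1cc(NC(=O)Nc2cccc(F)c2)cc(OC)c1OC` — in a functional assay on ONS-76 cells (Homo sapiens) for cytotoxicity, read by MTT assay, with a stated time of 72 h (on this read-out lower numbers stand for stronger inhibition and higher numbers for weaker inhibition), compound 1 gives 65600 nM.
Compound 2 `COc1cc(NC(=O)Nc2ccccc2)cc(OC)c1OC` — in this assay compound 2 gives "not determined" (no result reported).
Compound 3 `COc1cc(NC(=O)Nc2ccc([N+](=O)[O-])cc2)cc(OC)c1OC` — in this assay compound 3 gives 35000 nM.

Among the measured compounds shown here, only two numbers exist. Compound 3 holds the lower of them, yet its gap to compound 1 sits within the usual scatter, so the two cannot be ranked. Compound 4 `COc1ccc(NC(=O)Nc2cc(OC)c(OC)c(OC)c2)cc1` is not yet measured. It differs from compound 3 in one place: methoxy in place of nitro on an aromatic carbon. For the measured compounds named here, no pair of measured compounds shows such a change, so there is no guide to its effect. Going by the values given here, both numbers so far lie at the weak end, and a step within the scatter, in either direction, is expected for compound 4, as a 1.3-fold higher number from compound 3 to compound 4 (0.11 log units; within the scatter). Compound 4 is estimated at 45000 nM, within 15000 nM to 140000 nM.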

Compound 4, half-maximal inhibitory concentration: 12900 nM
Beside the measured number, compound 4's estimate is 3.5-fold (0.54 log units) above it, and the stated range ends above it.
By their numbers in this assay, from the lowest: compound 4; then compounds 3 and 1 (each within the scatter of the next).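

Methoxy in place of nitro, on an aromatic carbon para to a large group, gives a 2.7-fold lower number from compound 3 to compound 4 (0.43 log units; beyond the scatter) in this assay, so what sits on this carbon can move the number beyond the scatter. Exchanging 3-fluorophenyl for 4-methoxyphenyl on the amide-type nitrogen gives a 5.1-fold lower number from compound 1 to compound 4 (0.71 log units; beyond the scatter), and both steps are modest. Nothing available explains why the number falls with this change.

From the compounds shown here alone, how an amine, a hydroxyl group or a longer alkoxy chain on this carbon would compare with methoxy remains open.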